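From a Cyclic Amine Back to a Secondary Amine

The compounds below may be only part of what the source reports. "The series", "measured", "known", "first", "only" and "open" are said of these compounds alone.

Compound 1 `CCCCNc1cc(-c2ccccc2)nc2cc(OC)cc(OC)c12` gives 19600 nM in a functional assay on A549 cells (Homo sapiens) for inhibition, read by MTT assay, with a stated time of 72 h; on this read-out higher numbers stand for weaker inhibition and lower numbers for stronger inhibition.
Compound 2 `COc1cc(OC)c2c(-n3ccnc3)cc(-c3ccccc3)nc2c1` gives only a limit, > 100000 nM, in this assay.
Compound 3 `COc1cc(OC)c2c(N3CCCCC3)cc(-c3ccccc3)nc2c1` also gives only a limit, > 100000 nM, in this assay.

Compound 3 stands at the limit of this assay, the limit at which two of the three values sit (the limit of > 100000 nM in this assay, at which 2 of the 3 values shown sit); where it stands cannot be placed more closely than that. The step to compound 4 `COc1cc(OC)c2c(NCc3ccccc3)cc(-c3ccccc3)nc2c1` is benzylamino in place of piperidin-1-yl on an aromatic carbon. Among the compounds with values here, two measured steps bear on it in reverse: an at least 5.1-fold higher number from compound 1 to compound 3 (0.70 log units; beyond the scatter) and an at least 5.1-fold higher number from compound 1 to compound 2 (0.70 log units; beyond the scatter) both run from the butylamino of compound 1, which carries one hydrogen-bond donor, to a group without one. The step that the two limits leave unreadable from compound 2 to compound 3 gives no readable size. Compound 4 brings back a group with one hydrogen-bond donor, so the number is expected to fall again, and the expected step is an at least 5.0-fold lower number from compound 3 to compound 4 (0.69 log units; beyond the scatter), though its true size cannot be read from a limit. Compound 4 is therefore estimated at 20000 nM, with a range from 5000 nM to 80000 nM.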

Compound 4, half-maximal inhibitory concentration: 12800 nM
Estimate against measurement, compound 4: 1.6-fold (0.19 log units) above; measured number inside the range.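

Benzylamino on this aromatic carbon, opposite the ring nitrogen, gives a measured number in this assay, with an at least 7.8-fold lower number from compound 3 to compound 4 (0.89 log units; beyond the scatter) and an at least 7.8-fold lower number from compound 2 to compound 4 (0.89 log units; beyond the scatter). The carbon chain of the secondary amine can also carry a phenyl group: a 1.5-fold lower number from compound 1 to compound 4 (0.19 log units; within the scatter), so among the compounds shown, butylamino and benzylamino, which carry a hydrogen-bond donor, both give numbers, the two groups without one stay at the limit, and no compound goes against this. How far the two larger steps truly reach cannot be read: the limit of > 100000 nM in this assay, at which 2 of the 4 values shown sit.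

On these data alone, it remains open whether an open-chain dimethylamino group on this carbon would stay at the limit like piperidin-1-yl. Also open, as far as these compounds go, is whether a longer chain, such as hexylamino or phenethylamino, would move the number beyond the scatter.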